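The source may hold more compounds than are shown below. What is called first, only, known or untested is meant among the compounds shown, and "the series" means these compounds.

Three compounds share the measurements so far, and a fourth is still to be tested. Compound 1 `COc1nc(-c2cccc(Cl)c2)ccc1[C@@H](c1ccccc1)[C@@](O)(CCN(C)C)c1cccc2ccccc12` has no reported result in a toxicity assay on HeLa cells (Homo sapiens) for cytotoxicity (on this read-out higher numbers stand for lower toxicity in this test and lower numbers for higher toxicity in this test), where compound 1 shows only "nd" (no result reported). Compound 2 `COc1nc(-c2ccc(Br)cc2)ccc1[C@@H](c1ccccc1)[C@@](O)(CCN(C)C)c1cccc2ccccc12` was tested in this assay. In this assay compound 2 gives only > 64 ug/mL, which is a limit of the assay rather than a number. Compound 3 `COc1ncc(-c2ccccc2)cc1[C@@H](c1ccccc1)[C@@](O)(CCN(C)C)c1ccccc1` carries a different core, and in this assay compound 3 gives 11.9 ug/mL. Compound 2 therefore stands at the limit of > 64 ug/mL in this assay, at which 1 of the 3 values shown sits, and no single number places it more closely.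

Compound 4 `COc1ccc(-c2ccc([C@@H](c3ccccc3)[C@@](O)(CCN(C)C)c3cccc4ccccc34)c(OC)n2)cc1` differs from compound 2 in one place: methoxy in place of bromo on an aromatic carbon. Within the data shown here, no pair of measured compounds shows this same change, so no measured step tells how large its effect is. With only a limit for compound 2 as a starting point, the step of an at least 1.0-fold lower number from compound 2 to compound 4 (0.02 log units; that floor lies within the scatter) in this assay is expected to be no larger than the usual scatter, in either direction. Compound 4 is therefore expected to give about 60 ug/mL, within a range from 25 ug/mL to 130 ug/mL, with a fair chance that the result is once more reported only as a limit.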

Compound 4, half-maximal cytotoxic concentration: > 64 ug/mL
Compound 4 was reported as a limit; the forecaster's own chance of this, stated with the estimate: 55%; at least 1.0-fold (0.02 log units) between middle value and limit.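

Compound 2 and compound 4 each give a limit rather than a number, so no step between them can be read: the limit of > 64 ug/mL in this assay, at which 2 of the 4 values shown sit.

The compounds shown leave open how far the true value of either compound lies past that limit, and so whether swapping 4-bromophenyl for 4-methoxyphenyl changes the read-out at all.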